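The source may report more compounds than this note shows. Statements on the series, on what has been measured and on what is new or still open speak of the compounds shown alone.

Measured compounds, cytotoxicity on the shared core:

- compound 1, `CN(C)CCCNc1nc(-c2ccc(NC(=O)Nc3ccc(F)cc3)cc2)nc2c(Cl)c(Cl)sc12`: in a functional assay on NCI-H460 cells (Homo sapiens) for cytotoxicity, read by MTT assay, with a stated time of 72 h (on this read-out higher numbers stand for weaker inhibition and lower numbers for stronger inhibition), compound 1 gives 650 nM
- compound 2, `CN(C)CCCNc1nc(-c2ccc(NC(=O)Nc3ccc(Cl)cc3Cl)cc2)nc2ccsc12`: in this assay compound 2 gives 1020 nM
- compound 3, `CN(C)CCNc1nc(-c2ccc(NC(=O)Nc3ccccc3)cc2)nc2ccsc12`: in this assay compound 3 gives 640 nM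

The three numbers sit close together. Compound 1 lies nearest to compound 3, with a gap inside the usual scatter, and furthest from compound 2, with a gap that also stays inside the scatter. No pair among these differs in one place only, so no single-point step can be read from them.

Compound 4, `CN(C)CCCNc1nc(-c2ccc(NC(=O)Nc3ccc(Cl)cc3Cl)cc2)nc2c(Cl)c(Cl)sc12`, is not yet measured. It is derived from compound 1 by 2,4-dichlorophenyl in place of 4-fluorophenyl on an amide-type nitrogen. Compound 2 carries the same 2,4-dichlorophenyl on a core without the two chlorines, and its value against compound 1 and compound 3 stays within the scatter; nothing here points to a step beyond the scatter for this change. Compound 4 is therefore expected at 800 nM, between 350 nM and 1800 nM, and the step from compound 1 to compound 4 is estimated at a 1.2-fold higher number from compound 1 to compound 4 (0.09 log units; within the scatter), within the scatter.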

Compound 4, half-maximal inhibitory concentration: 980 nM
The estimate for compound 4 lay 1.2-fold (0.09 log units) below the measured number, and the stated range covers the measured number.
By their numbers in this assay, from the lowest: compounds 3, 1, 4 and 2 (each within the scatter of the next).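

In this assay, the series now has its first single-point step on the amide-type nitrogen: 2,4-dichlorophenyl in place of 4-fluorophenyl gives a 1.5-fold higher number from compound 1 to compound 4 (0.18 log units; within the scatter). On the core of compound 1, this aryl change therefore produces no difference beyond the scatter, although this rests on one pair only. No accompanying measurement bears on this step.

As far as these compounds go, it remains open whether any group on this nitrogen can move the number beyond the scatter, for instance a phenyl carrying an amine or a carboxylic acid in place of the halogens. These compounds also cannot show whether the same change gives a similar step on a core without the two chlorines.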